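Pentylsulfanyl in Place of Ethyl on a Fused Core

This account rests on a few compounds, and the source may have more. Where it says the series, first, only, none or still open, it means among the compounds named here.

Of the compounds shown here, two have been measured in a functional assay (spleen, spleen) for activation, with Mus musculus as the target; a higher number here means that more compound is needed for the effect, a lower number that less compound is needed. Compound 1, `Nc1ncnc2c1nc(O)n2Cc1ccc(Cl)cc1`, gives 10 uM in this assay. Compound 2, `CCc1nc(N)c2nc(O)n(Cc3ccccc3)c2n1`, gives 1 uM in this assay, the lowest of the two numbers; the gap between compound 1 and compound 2 lies beyond the usual scatter, so compound 2 needs less compound for the effect than compound 1 does.

The step under consideration leads from compound 2 to compound 3, `CCCCCSc1nc(N)c2nc(O)n(Cc3ccccc3)c2n1`, which has not yet been measured in this assay. The change is pentylsulfanyl in place of ethyl on an aromatic carbon, on an aromatic carbon of a six-membered aromatic ring with two nitrogen atoms, between two ring nitrogen atoms. Within the data shown here, nothing among the measured compounds shows what such a change does here, since no pair that differs in only this place has been measured. Given that compound 2 already gives 1 uM, a modest step toward a lower number is expected, a 3.3-fold lower number from compound 2 to compound 3 (0.52 log units; beyond the scatter). Compound 3 is therefore estimated to give 0.3 uM in this assay, with a range from 0.03 uM to 3 uM.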

Compound 3, minimum effective concentration: 10 uM
Compound 3: middle estimate off by 33-fold (1.52 log units), on the low side; measured number outside the range, above it.
By their numbers in this assay, from the lowest: compound 2; then compounds 1 and 3 (each within the scatter of the next).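

In this assay, among these compounds, the place on an aromatic carbon of the six-membered aromatic ring with 2 nitrogen, between two ring nitrogen atoms, proves sensitive to what it carries: pentylsulfanyl in place of ethyl gives a 10-fold higher number from compound 2 to compound 3 (1.00 log units; beyond the scatter) and so provides the only pair here that differs in one place. The earlier compounds shown here said nothing about this position, whereas this pair shows that the larger group, with 6 heavy atoms against 2 and a sulfur atom on the ring, goes with more compound being needed for the effect, not less. The compounds shown offer no measurement that accounts for the direction or size of this step.

This one step cannot separate the sulfur atom from the length of the chain: a pentyl group joined directly through carbon, or a short methylsulfanyl or ethylsulfanyl group, would be needed to tell which part goes with the higher number. Also open, as far as these compounds go, is how an amine such as butylamino or a chain ending in a hydroxyl group would compare with ethyl at this position on the shared core.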